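The source may hold more compounds than are shown below. What is called first, only, known or untested is meant among the compounds shown, and "the series" means these compounds.

Compound 1 `COc1cccc(Oc2ccc3c(NCCCNCc4ccco4)ccnc3c2)c1` gives 14500 nM in a physicochemical assay for solubility, with a stated time of 18 h, at pH 7.4 (a lower number here means a less soluble compound, a higher number a more soluble compound), standing level with compound 2 `COc1cccc(Oc2ccc3c(NCCCNCc4cccc(OC)c4O)ccnc3c2)c1`, which gives 14500 nM; the step of no change at the digits printed from compound 1 to compound 2 (within the scatter) shows that change leaving the read-out unmoved. Compound 3 `Clc1ccc(Oc2ccc3c(NCCCNCc4ccco4)ccnc3c2)cc1` differs from compound 1 at another place: 4-chlorophenyl in place of 3-methoxyphenyl on an oxygen on an aromatic ring. Going by the values given here, no measured step touches this position, so the one step on record gives little guidance. A modest drop is expected, though perhaps not beyond the scatter. For compound 3 the estimated step is a 1.8-fold lower number from compound 1 to compound 3 (0.26 log units; within the scatter), giving an expected value of 8000 nM, in a range from 3000 nM to 20000 nM.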

Compound 3, solubility: 14500 nM
For compound 3 the middle estimate is 1.8-fold (0.26 log units) below the measured one; measured number inside the range.
By their numbers in this assay, from the lowest: compounds 1, 2 and 3 (each within the scatter of the next).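

Replacing 3-methoxyphenyl with 4-chlorophenyl on an oxygen on an aromatic ring gives in this assay no change at the digits printed from compound 1 to compound 3 (within the scatter). Going by these compounds alone, this is the first measured change at this position, and it shows that the read-out tolerates the exchange of one substituted phenyl for another with a different substituent at a different ring position. No measured evidence here accounts for this result. The compounds shown leave open whether an amine or a carboxylic acid in place of 4-chlorophenyl would keep the read-out level.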